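Replacing the methoxycarbonyl of compound 1 with ethoxymethyl

A few compounds are considered here, and "the series" means these few. Any claim that something is new, unique, unknown or untested is made for them only; others in the source may bear on it.

Compound 1 `CCc1cccc2c(OC)c(-c3occ(C)c3C(=O)OC)ccc12` gives 1.3 ug/mL in a functional assay on MDA-MB-231 cells (Homo sapiens) for cytotoxicity, read by MTT assay, with a stated time of 72 h (on this read-out higher numbers stand for an effect only at larger amounts of compound and lower numbers for an effect already at smaller amounts), and compound 2 `CCOc1c(-c2occ(C)c2C(=O)OC)ccc2c(CC)cccc12` gives 1.2 ug/mL, so the two sit together within the scatter. Going by the values given here, the only measured step, a 1.1-fold lower number from compound 1 to compound 2 (0.03 log units; within the scatter), concerns a different place on the shared core and does not bear on compound 3 `CCOCc1c(C)coc1-c1ccc2c(CC)cccc2c1OC`, which carries ethoxymethyl in place of methoxycarbonyl on an aromatic carbon. Among the compounds with values here, no measured step touches this position, so the expected change is none beyond the scatter, with wide uncertainty. Compound 3 is estimated at 1.5 ug/mL, with a range from 0.6 ug/mL to 4 ug/mL. This expectation amounts to a 1.2-fold higher number from compound 1 to compound 3 (0.06 log units; within the scatter).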

Compound 3, concentration for half-maximal effect: 9.1 ug/mL
Estimate against measurement, compound 3: 6.1-fold (0.78 log units) below; measured number outside the range, above it.
By their numbers in this assay, from the lowest: compounds 2 and 1 (each within the scatter of the next); then compound 3.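

The position two ring bonds from the ring oxygen proves sensitive in this assay to ethoxymethyl in place of methoxycarbonyl, with a 7.0-fold higher number from compound 1 to compound 3 (0.85 log units; beyond the scatter) for this exchange. Both groups count 4 heavy atoms, so the step arises without a change in that count, while methoxycarbonyl has 2 hydrogen-bond acceptors and ethoxymethyl has 1. Nothing available ties the step to any particular difference between the two groups.

Open, as far as these compounds go, is whether a carboxylic acid, a primary amide or hydroxymethyl at this position would stay near compound 1 or shift like compound 3. A longer ester chain is equally unresolved.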